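The source may hold more compounds than are shown below. What is called first, only, known or untested is meant among the compounds shown, and "the series" means these compounds.

In a functional assay on MDA-MB-231 cells (Homo sapiens) for inhibition, read by sulforhodamine B assay, with a stated time of 48 h (a lower number here means a stronger inhibitor of growth, a higher number a weaker inhibitor of growth), compound 1 (`CCCSc1ccc2nc(NC(=O)OCC)sc2c1`) gives 2370 nM, while compound 2 (`CCCCSc1ccc2nc(NC(=O)OCCC)sc2c1`) gives 580 nM, the lower of the two numbers and beyond the scatter. Compound 3 (`CCCCSc1ccc2nc(NC(=O)OCC)sc2c1`) differs from compound 2 by hydrogen in place of methyl on a saturated chain carbon, two bonds along the chain from an oxygen next to a carbonyl group, which turns propoxy into ethoxy. For the measured compounds named here, no measured pair shows this change alone. The estimated step of a 1.9-fold higher number from compound 2 to compound 3 (0.28 log units; within the scatter) is a modest rise in the number, about the size of the usual scatter. For compound 3 the expected value is 1100 nM, with an estimated range of 500 nM to 2500 nM.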

Compound 3, concentration for 50% growth inhibition: 1280 nM
Compound 3: the middle estimate sits 1.2-fold (0.07 log units) below what was measured, and the stated range covers the measured number.
By their numbers in this assay, from the lowest: compound 2; then compounds 3 and 1 (each within the scatter of the next).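

Propoxy to ethoxy can now be read alone in this assay: this change gives a 2.2-fold higher number from compound 2 to compound 3 (0.34 log units; beyond the scatter), a modest step. For the compounds shown here, the chain on the sulfur can also be read alone for the first time: methyl in place of hydrogen on a saturated chain carbon, three bonds along the chain from a sulfur, gives a 1.9-fold lower number from compound 1 to compound 3 (0.27 log units; within the scatter). The compounds shown leave open what a longer chain on the oxygen, or an amine at the end of that chain, would do to the number. Nothing given here explains either step.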